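Epimer of compound 3 at the chain stereocentre

The source may hold more compounds than are shown below. What is called first, only, known or untested is meant among the compounds shown, and "the series" means these compounds.

Three compounds of the series have been run in a functional assay on HBL-100 cells (Homo sapiens) for antiproliferative activity, read by luminescence and CellTiter-Glo, with a stated time of 48 h; on this read-out lower numbers stand for stronger inhibition and higher numbers for weaker inhibition. Within the data shown here, compound 1 `O=C1C=CC[C@H](/C=C/C2CCCCC2)O1` is the only one with an unsaturated core, and in this assay compound 1 gives 29000 nM. Compound 2 `O=C1CCC[C@H]([C@H]2C[C@@H]2c2ccccc2)O1` has a saturated core; in this assay compound 2 is reported only as a limit, > 100000 nM. Compound 3 `C[C@@H](Cc1ccccc1)[C@H]1CCCC(=O)O1` shares the saturated core of compound 2 and carries a branched side chain; in this assay compound 3 is likewise reported as a limit, > 100000 nM. Compound 3 thus stands at the weak end of what is shown: the limit of > 100000 nM in this assay, at which 2 of the 3 values shown sit, and compound 1 is the only member with an actual number.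

Compound 4 `C[C@H](Cc1ccccc1)[C@H]1CCCC(=O)O1` is the partner of compound 3: the two compounds have the same atoms and bonds and differ only in configuration as drawn: 1 of 2 stereo elements differ; a stereocentre at a saturated chain carbon is drawn S in compound 3 and R in compound 4. Among the measured compounds shown here, no step between two measured compounds is available for this kind of change, so the expectation rests on the limit of compound 3 alone. The step of a number no higher from compound 3 to compound 4 (the limit leaves the size open) is expected to lie within the scatter, with a limit again the most likely result. For compound 4 the estimate in this assay is 100000 nM, within 30000 nM to 300000 nM.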

Compound 4, half-maximal inhibitory concentration: > 100000 nM
Compound 4: only a limit was reported (the forecaster's own chance of this, stated with the estimate: 80%); the middle value sits exactly at the limit.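

Compound 3 and compound 4 are both reported only as limits in this assay, so no step can be read between them. The compounds shown leave open whether the configuration drawn at the saturated chain carbon makes any difference to antiproliferative activity, and what actual value either compound would give.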